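Phenyl group change from compound 3 to compound 4

The compounds below may be only part of what the source reports. "The series", "measured", "known", "first", "only" and "open" are said of these compounds alone.

Values in a functional assay on MIA PaCa-2 cells (Homo sapiens) for inhibition, read by MTT assay, with a stated time of 48 h, tested at 10 uM (a lower number here means less inhibition of growth, a higher number more inhibition of growth at the concentration tested), are as follows.
- compound 1 `Cc1cc(=O)c2c(O)c(CN3CCC(N4CCCCC4)CC3)c(O)c([C@H]3CCN(C)C[C@H]3O)c2o1` gives 23%
- compound 2 `Cc1cc(=O)c2c(O)c(CN(C(C)C)C(C)C)c(O)c([C@H]3CCN(C)C[C@H]3O)c2o1` gives 11%
- compound 3 `Cc1oc2c([C@H]3CCN(C)C[C@H]3O)c(O)cc(O)c2c(=O)c1C(O)c1ccc(F)c(Br)c1` gives 9%

Compound 3 at 9% lies within the scatter of compound 2 at 11%. Compound 1 gives 23%, and the gap from compound 3 to it exceeds the scatter, with compound 3 the lower of the two.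

Compound 4 `CCOc1ccc(Br)c(C(O)c2c(C)oc3c([C@H]4CCN(C)C[C@H]4O)c(O)cc(O)c3c2=O)c1` has not yet been measured. It carries 2-bromo-5-ethoxyphenyl in place of 3-bromo-4-fluorophenyl on a saturated chain carbon bound to an aromatic carbon and an oxygen on a saturated carbon.

Among the compounds with values here, no measured pair isolates a change at this place, so the data give no size for such a step. Within the data shown here, the expectation therefore rests on compound 3 at 9%, the only measured compound with a substituted phenyl group at this place. No shift beyond the scatter is expected in this assay. The expected step of a number 3 percentage points higher from compound 3 to compound 4 (within the scatter) is small and upward. For compound 4 the estimated value is 12%, with an expected range of 3% to 25%.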

Compound 4, percent growth inhibition at one concentration: 4%
For compound 4 the middle estimate is 8 percentage points above the measured one, and the stated range covers the measured number.
By their numbers in this assay, from the lowest: compounds 4, 3 and 2 (each within the scatter of the next); then compound 1.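

In this assay, within the data shown here, placing 2-bromo-5-ethoxyphenyl in place of 3-bromo-4-fluorophenyl on a saturated chain carbon bound to an aromatic carbon and an oxygen on a saturated carbon gives a number 5 percentage points lower from compound 3 to compound 4 (within the scatter), the first step that can be read at this place. This exchange, which brings in a hydrogen-bond acceptor absent from the leaving group and removes the fluorine, leaves the read-out within the usual scatter, so this place tolerates the change without a measurable shift in growth inhibition at the concentration tested. No available measurement accounts for the size of this step.

The exchange alters the bromine placement and the second substituent together, so their separate contributions cannot be read. On these data alone, whether an unsubstituted phenyl, or a phenyl carrying an amine or a carboxylic acid, would behave differently at this place remains open.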